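The compounds below may be only part of what the source reports. "The series", "measured", "known", "first", "only" and "open" are said of these compounds alone.

Measured in a functional assay on the whole organism (Tail, strain ICR) with Mus musculus as the target, in the tail flick test, with a stated time of 150 min, at a dose of 25 umol/kg by the oral route; on this read-out higher numbers stand for a stronger effect at the one dose given and lower numbers for a weaker effect:
compound 1, `N=C(N)NCCC[C@H](NC(=O)CN(c1ncnc2c1ncn2C1CCCCO1)C1CC1)C(=O)OCc1ccccc1`: 19.6%
compound 2, `NCCCC[C@H](NC(=O)CN(c1nc(Cl)nc2[nH]cnc12)C1CC1)C(=O)OCc1ccccc1`: 9.88%

On the two numbers at hand compound 1 stands highest, with compound 2 the nearest number, lower by an amount that lies within the usual scatter; the two results therefore cannot be told apart, and neither compound can be called the more active. Both readings sit in the lower part of the read-out.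

Compound 3, `NC(=O)C[C@H](NC(=O)CN(c1ncnc2c1ncn2C1CCCCO1)C1CC1)C(=O)OCc1ccccc1`, has not yet been measured in this assay. Against compound 1 the change is a group of 3 heavy atoms (1 carbon, 1 nitrogen, 1 oxygen; no ring) in place of a group of 6 heavy atoms (3 carbon, 3 nitrogen; no ring), on a saturated chain carbon, two bonds along the chain from an amide-type nitrogen and a carbonyl carbon. For the measured compounds named here, no pair of measured compounds differs from each other in one place, so there is no measured step on which to size this exchange. With both measured values low and no anchor, a step on the small side is expected, if anything downward, and not beyond the scatter. The step from compound 1 to compound 3 is expected to be a number 6.6 percentage points lower from compound 1 to compound 3 (within the scatter). Compound 3 is estimated at 13%, with a range from 3% to 27%.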

Compound 3, a percentage reported as activity, at one dose (the size of the read-out at that dose, not a potency): 21.7%
The estimate for compound 3 lay 8.7 percentage points below the measured number; measured number inside the range.
By their numbers in this assay, from the lowest: compounds 2, 1 and 3 (each within the scatter of the next, the first and the last beyond it).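

In this assay, for the compounds shown here, carbamoyl in place of the group of 6 heavy atoms (3 carbon, 3 nitrogen; no ring), on a saturated chain carbon, two bonds along the chain from an amide-type nitrogen and a carbonyl carbon, gives a number 2.1 percentage points higher from compound 1 to compound 3 (within the scatter), the first step that can be read at this position. On the core shared by this pair, the read-out therefore does not separate carbamoyl, with 3 heavy atoms and 1 hydrogen-bond donor, from the larger group, with 6 heavy atoms and 3 hydrogen-bond donors, so at this one dose the larger group is not needed to keep the reading at this level. No measurement at hand bears on the origin of this result.

Going by these compounds, compound 2 differs from the other two compounds in more than one place, so its steps to them cannot be read, and what its own changes contribute stays open. Also open, on these data alone, is whether a carboxylic acid, a simple amine or a longer chain ending in carbamoyl on this chain carbon would move the reading beyond the scatter.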